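The source may hold more compounds than are shown below. What is called first, only, known or untested is meant among the compounds shown, and "the series" means these compounds.

Compounds measured in a functional assay on MNK45 cells (Homo sapiens) for inhibition, read by MTT assay, with a stated time of 48 h; on this read-out higher numbers stand for weaker inhibition and lower numbers for stronger inhibition:
compound 1 `Cc1ccc(NC(=O)NC(=O)c2ccc(OCc3cccc(F)c3)cc2)cc1-c1nc2ccccc2[nH]1` — 53000 nM
compound 2 `Cc1ccc(NC(=O)NC(=O)c2ccc(OCc3ccccc3Cl)cc2)cc1-c1nc2ccccc2[nH]1` — 21500 nM
compound 3 `Cc1ccc(NC(=O)NC(=O)c2ccc(OCc3ccc(Cl)c(Cl)c3)cc2)cc1-c1nc2ccccc2[nH]1` — 5820 nM

Compound 3 stands at the lowest number of the three in this assay; the steps reaching it, a 9.1-fold lower number from compound 1 to compound 3 (0.96 log units; beyond the scatter) and a 3.7-fold lower number from compound 2 to compound 3 (0.57 log units; beyond the scatter), both lie beyond the scatter. Compound 4 `Cc1ccc(NC(=O)NC(=O)c2ccc(OCc3ccc(F)cc3)cc2)cc1-c1nc2ccccc2[nH]1` differs from compound 3 in one place: 4-fluorophenyl in place of 3,4-dichlorophenyl on a saturated chain carbon bound to an oxygen on an aromatic ring. Within the data shown here, the steps that bear on this change are a 2.5-fold lower number from compound 1 to compound 2 (0.39 log units; beyond the scatter), a 9.1-fold lower number from compound 1 to compound 3 (0.96 log units; beyond the scatter) and a 3.7-fold lower number from compound 2 to compound 3 (0.57 log units; beyond the scatter). Across them, the single fluorine of compound 1 gave the highest number and the two chlorines of compound 3 the lowest. Moving back to a single fluorine, now 4-fluorophenyl, is therefore expected to raise the number. For compound 4 this is expected to mean a 5.2-fold higher number from compound 3 to compound 4 (0.71 log units; beyond the scatter). Compound 4 is estimated at 30000 nM, within 10000 nM to 90000 nM.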

Compound 4, half-maximal inhibitory concentration: 240 nM
Compound 4: the middle estimate sits 130-fold (2.10 log units) above what was measured; measured number below the stated range.
By their numbers in this assay, from the lowest: compound 4; then compound 3; then compound 2; then compound 1.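

In this assay, among these compounds, the group on this saturated chain carbon matters far more than the earlier compounds showed: 4-fluorophenyl in place of 3-fluorophenyl gives a 220-fold lower number from compound 1 to compound 4 (2.34 log units; beyond the scatter) while the halogen count stays the same. It also outdoes both chlorine-bearing groups, with a 90-fold lower number from compound 2 to compound 4 (1.95 log units; beyond the scatter) and a 24-fold lower number from compound 3 to compound 4 (1.38 log units; beyond the scatter) in the same assay. Halogen count therefore does not order these compounds, as compound 4 has the lowest number and compound 1, also with one fluorine, the highest. Going by these compounds, whether a chlorine or a methoxy group in place of the fluorine of 4-fluorophenyl would keep so low a number remains open, as does the plain unsubstituted phenyl. No evidence is available to account for this result.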